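Methyl to methoxy on the anilide ring of compound 2

This account rests on a few compounds, and the source may have more. Where it says the series, first, only, none or still open, it means among the compounds named here.

Compound 2 `Cc1ccc(NC(=O)C2(C(=O)Nc3ccc(Nc4ncc5cc(C(=O)N(C)C)n(C6CCCC6)c5n4)cc3)CC2)cc1` stands second highest of the three numbers in a functional assay on A549 cells (Homo sapiens) for inhibition, read by CCK-8 assay, with a stated time of 72 h, tested at 10 uM (on this read-out higher numbers stand for more inhibition of growth at the one concentration tested and lower numbers for less inhibition of growth), giving 90.6%, though both gaps lie within the scatter: compound 1 `CN(C)C(=O)c1cc2cnc(Nc3ccc(NC(=O)C4(C(=O)Nc5ccccc5)CC4)cc3)nc2n1C1CCCC1` gives 88.8% and compound 3 `COc1cccc(NC(=O)C2(C(=O)Nc3ccc(Nc4ncc5cc(C(=O)N(C)C)n(C6CCCC6)c5n4)cc3)CC2)c1` gives 96%, with a number 1.8 percentage points higher from compound 1 to compound 2 (within the scatter) and a number 5.4 percentage points higher from compound 2 to compound 3 (within the scatter). Compound 4 `COc1ccc(NC(=O)C2(C(=O)Nc3ccc(Nc4ncc5cc(C(=O)N(C)C)n(C6CCCC6)c5n4)cc3)CC2)cc1` differs from compound 2 by methoxy in place of methyl on an aromatic carbon. Among the compounds with values here, the steps that bear on this are a number 7.2 percentage points higher from compound 1 to compound 3 (within the scatter), where methoxy enters on an aromatic carbon, and a number 5.4 percentage points higher from compound 2 to compound 3 (within the scatter), where a methoxyphenyl replaces a methylphenyl; neither exceeds the scatter. No step beyond the scatter is therefore expected here, with a number 0.4 percentage points higher from compound 2 to compound 4 (within the scatter) taken as the expected change. Compound 4 is estimated at 91%, with a range from 84% to 97%.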

Compound 4, percent growth inhibition at one concentration: 78.5%
For compound 4 the middle estimate is 12.5 percentage points above the measured one, and the stated range ends above it.
By their numbers in this assay, from the lowest: compound 4; then compounds 1, 2 and 3 (each within the scatter of the next).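

In this assay, within the data shown here, methoxy para to a large group gives what no earlier step gave, a change beyond the scatter: a number 12.1 percentage points lower from compound 2 to compound 4 (beyond the scatter) and a number 10.3 percentage points lower from compound 1 to compound 4 (beyond the scatter) while methoxy in compound 3 brought no such step. Where the methoxy sits on the ring therefore counts as well as its presence, with a number 17.5 percentage points lower from compound 3 to compound 4 (beyond the scatter) on going from 3-methoxyphenyl to 4-methoxyphenyl. Nothing at hand explains this drop. On these data alone, whether a hydroxyl, an amine or a longer ether such as ethoxy in the same place follows methoxy or methyl remains open.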